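Thiophene for chlorophenyl on a sulfonyl in a shared core

The source may hold more compounds than are shown below. What is called first, only, known or untested is meant among the compounds shown, and "the series" means these compounds.

Compound 1 `CN1CCN(c2ccc3[nH]nc(S(=O)(=O)c4ccccc4Cl)c3c2)CC1` gives 100% in a functional assay on HeLa cells for antagonist activity at 5-hydroxytryptamine receptor 6 (Homo sapiens) (a higher number here means a larger maximal response, a lower number a smaller maximal response), and stands level with compound 2 `CC(C)Cn1nc(S(=O)(=O)c2cccc3ccccc23)c2cc(N3CCN(C)CC3)ccc21` at 100% and compound 3 `CCn1nc(S(=O)(=O)c2cccc3ccccc23)c2cc(N3CCN(C)CC3)ccc21` at 100%. Going by the values given here, the only single-point step measured, no change at the digits printed from compound 2 to compound 3 (within the scatter), concerns the chain on the aromatic nitrogen and not the group on the sulfonyl sulfur. Compound 4 `CN1CCN(c2ccc3[nH]nc(S(=O)(=O)c4cccs4)c3c2)CC1` differs from compound 1 by thiophen-2-yl in place of 2-chlorophenyl on a sulfonyl sulfur. Among the compounds with values here, no measured step touches that position; compounds 2 and 3, which carry a different group there, merely show the same value as compound 1. Since every measured compound reaches the same maximal response, compound 4 is expected to do the same, with a step of no change at the digits printed from compound 1 to compound 4 (within the scatter). Compound 4 is estimated at 100%, within 85% to 105%.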

Compound 4, largest response reached (reported as Imax), in percent of the reference or control that the assay uses: 96%
The estimate for compound 4 lay 4 percentage points above the measured number, within the range that was stated.
By their numbers in this assay, from the lowest: compounds 4, 1, 2 and 3 (each within the scatter of the next).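

Going by these compounds alone, this is the first step measured at the group on the sulfonyl sulfur: thiophen-2-yl in place of 2-chlorophenyl gives a number 4 percentage points lower from compound 1 to compound 4 (within the scatter) in this assay. At this position, a five-membered aromatic ring with 1 hetero atom therefore serves as well as the chlorinated six-membered ring, so the chlorine is not required for this maximal response. Nothing measured here accounts for this result.

On these data alone, it remains open whether a non-aromatic group on the sulfonyl sulfur, such as cyclohexyl, would hold this response. Also open, as far as these compounds go, is whether thiophen-2-yl would do so with an ethyl chain on the aromatic nitrogen.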